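From sulfonyl to sulfanyl under a solubility limit

The source may report more compounds than this note shows. Statements on the series, on what has been measured and on what is new or still open speak of the compounds shown alone.

Measured in a physicochemical assay for solubility; a higher number here means a more soluble compound, a lower number a less soluble compound:
compound 1 `O=C(O)c1ccc(C(=O)/C(=C\c2ccc(F)c([N+](=O)[O-])c2)S(=O)(=O)Cc2ccc(Br)cc2)cc1`: < 1000 ug/mL
compound 2 `COc1cc(/C=C(/SCc2ccc(Br)cc2)C(=O)c2ccc(C(=O)O)cc2)ccc1F`: < 1000 ug/mL
compound 3 `O=C(O)c1ccc(C(=O)/C(=C\c2ccc(Cl)c([N+](=O)[O-])c2)S(=O)(=O)Cc2ccc(Br)cc2)cc1`: < 1000 ug/mL

Each of these entries is a limit of the assay and not a number. Compound 1 gives < 1000 ug/mL, which is such a limit. The other two measured compounds share it, as the limit of < 1000 ug/mL in this assay, at which 3 of the 3 values shown sit, shows, so no order among the three can be read.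

Compound 4 `O=C(O)c1ccc(C(=O)/C(=C\c2ccc(F)c([N+](=O)[O-])c2)SCc2ccccc2Cl)cc1` has not yet been measured. Its difference from compound 1 is this: (2-chlorobenzyl)sulfanyl in place of (4-bromobenzyl)sulfonyl on a double-bonded chain carbon bound to a carbonyl carbon and a double-bonded chain carbon. In words, (2-chlorobenzyl)sulfanyl stands in place of (4-bromobenzyl)sulfonyl on a double-bonded chain carbon bound to a carbonyl carbon and a double-bonded chain carbon.

For the measured compounds named here, only one measured step is available, a step that the two limits leave unreadable from compound 1 to compound 3. It is chloro in place of fluoro on an aromatic carbon, and it leaves the group changing here untouched. With no readable size, it gives no guide to the size or direction of this change in this assay. Compound 4 is therefore expected to report the same limit as the others, and no direction can be expected. The expected step is a step that the limit leaves unreadable from compound 1 to compound 4. Compound 4 is estimated at 400 ug/mL, with an expected range from 80 ug/mL to 1000 ug/mL.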

Compound 4, solubility: < 1000 ug/mL
Compound 4: a limit, no number; the forecaster's own chance of this, stated with the estimate: 85%; the middle value lies beyond the limit too.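

In this assay compound 4 gives < 1000 ug/mL as a limit of the assay and not a number. For the compounds shown here, no step from compound 1 to compound 4 can be read, since both compounds sit at the same limit: the limit of < 1000 ug/mL in this assay, at which 4 of the 4 values shown sit. The compounds shown leave open how far any of them lies from that limit, and whether (2-chlorobenzyl)sulfanyl in place of (4-bromobenzyl)sulfonyl moves the read-out at all.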